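A few compounds are considered here, and "the series" means these few. Any claim that something is new, unique, unknown or untested is made for them only; others in the source may bear on it.

Working notes on the series. Going by the values given here, in a functional assay (thoracic aorta) for inhibition, with Rattus norvegicus as the target (on this read-out lower numbers stand for stronger inhibition and higher numbers for weaker inhibition), compound 1 `O=C(O)c1cc(CCCNS(=O)(=O)c2ccccc2)c2cccccc1-2` gives 4800 nM, the higher of the two numbers so far. Compound 2 `O=C(O)c1cc(CCCCCCCCNS(=O)(=O)c2ccccc2)c2cccccc1-2` gives 38 nM, which is lower by a margin well beyond the usual scatter. Compound 1 is therefore the weaker of the two measured compounds in this series.

Compound 3 `CC(C)c1ccc2c(CCCNS(=O)(=O)c3ccccc3)cc(C(=O)O)c-2cc1` keeps the core of compound 1 and carries a single change: isopropyl in place of hydrogen on an aromatic carbon. Among the compounds with values here, no measured pair shows this change, so the expectation rests on the structural change alone and remains uncertain, in size and in direction. A modest move towards a lower number, not far beyond the scatter, is expected, as a 2.7-fold lower number from compound 1 to compound 3 (0.43 log units; beyond the scatter). For compound 3 the estimated value in this assay is 1800 nM, with an expected range of 400 nM to 7000 nM.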

Compound 3, half-maximal inhibitory concentration: 4800 nM
The estimate for compound 3 lay 2.7-fold (0.43 log units) below the measured number; the measured number falls inside the stated range.
By their numbers in this assay, from the lowest: compound 2; then compounds 1 and 3 (each within the scatter of the next).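

Isopropyl in place of hydrogen on an aromatic carbon brings no change at the digits printed from compound 1 to compound 3 (within the scatter) in this assay. Going by these compounds alone, this is the first reading at this position: on a seven-membered aromatic ring of carbon only, part of a fused or bridged system of two rings, a group of 3 heavy atoms leaves the number in this read-out where it stood with hydrogen, at least with the chain of compound 1. No outside measurement on hand bears on this result.

Open, on these data alone, is whether isopropyl at this position would give the same flat reading on the chain of compound 2. Also open, as far as these compounds go, is whether an amine or a carboxylic acid on the same aromatic carbon would leave the number equally unmoved.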